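A few compounds are considered here, and "the series" means these few. Any claim that something is new, unique, unknown or untested is made for them only; others in the source may bear on it.

Compound 1 `Cc1cc(Nc2cc(-c3ccccc3)[nH]n2)n2nc(SCc3ccccc3Br)nc2n1`: 3650 nM
Compound 2 `Cc1cc(Nc2cc(C(C)(C)C)[nH]n2)n2nc(SCc3ccc(Br)cc3)nc2n1`: 5620 nM
Compound 3 `Cc1cc(Nc2ccn(Cc3ccc(F)cc3)n2)n2nc(SCc3ccc(Br)cc3)nc2n1`: 3070 nM

All three were tested in a functional assay on MGC-803 cells (Homo sapiens) for inhibition, read by MTT assay, with a stated time of 72 h; on this read-out lower numbers stand for stronger inhibition and higher numbers for weaker inhibition. Compound 1 stands second highest of the three numbers, with compound 3 at a slightly lower number and compound 2 at a slightly higher one, both within the usual scatter, so no order among the three can be claimed. Compound 4 `Cc1cc(Nc2cc(-c3ccccc3)[nH]n2)n2nc(SCc3csc4ccccc34)nc2n1` has not yet been measured. It differs from compound 1 in one place: 1-benzothiophen-3-yl in place of 2-bromophenyl on a saturated chain carbon bound to a sulfur. Among the measured compounds shown here, no measured pair shows this kind of change, so the expectation rests only on the narrow spread of compounds 1 to 3. The expected step is a 1.2-fold lower number from compound 1 to compound 4 (0.09 log units; within the scatter), none beyond the scatter. Compound 4 is therefore estimated at 3000 nM, within a range from 1200 nM to 8000 nM.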

Compound 4, half-maximal inhibitory concentration: 2280 nM
Estimate against measurement, compound 4: 1.3-fold (0.12 log units) above; low and high end bracket the measured number.
By their numbers in this assay, from the lowest: compounds 4, 3, 1 and 2 (each within the scatter of the next, the first and the last beyond it).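

In this assay, among the compounds shown here, the first step at this position is a 1.6-fold lower number from compound 1 to compound 4 (0.20 log units; within the scatter), with 1-benzothiophen-3-yl in place of 2-bromophenyl on the saturated chain carbon bound to a sulfur. The swap to a group of 9 heavy atoms from one of 7, with the bromine gone, therefore gives no change that can be told from the usual scatter. No evidence bears on the reason for this result. As far as these compounds go, whether a non-aromatic group at this place, such as a cyclohexyl ring, an amine or a carboxylic acid, would shift the number beyond the scatter remains open.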